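A Sulfonamide Aryl Swap Within a Narrow Range

This account rests on a few compounds, and the source may have more. Where it says the series, first, only, none or still open, it means among the compounds named here.

In a functional assay on MCF7 cells (Homo sapiens) for antiproliferative activity, read by sulforhodamine B assay, with a stated time of 48 h (on this read-out lower numbers stand for stronger inhibition and higher numbers for weaker inhibition), compound 1 (`CCc1ccccc1NS(=O)(=O)c1ccc(N2CCNC2=O)cc1`) gives 350 nM, compound 2 (`Cc1cccc(NS(=O)(=O)c2ccc(N3CCNC3=O)cc2)c1`) gives 190 nM and compound 3 (`O=C1NCCN1c1ccc(S(=O)(=O)Nc2ccc(Br)cc2)cc1`) gives 240 nM. Compound 3 cannot be separated from the other two on these numbers. Compound 4 (`Cc1cccc(NS(=O)(=O)c2ccc(N3CCNC3=O)cc2)c1C`) carries 2,3-dimethylphenyl in place of 4-bromophenyl on a sulfonamide nitrogen. Three measured swaps at that nitrogen bear on this change: a 1.8-fold lower number from compound 1 to compound 2 (0.27 log units; within the scatter), a 1.5-fold lower number from compound 1 to compound 3 (0.16 log units; within the scatter) and a 1.3-fold higher number from compound 2 to compound 3 (0.10 log units; within the scatter). All three lie within the scatter, so no step beyond it, in either direction, is expected in this assay. The expected change is a 1.1-fold lower number from compound 3 to compound 4 (0.04 log units; within the scatter). Compound 4 is estimated at 220 nM, with an expected range of 100 nM to 480 nM.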

Compound 4, half-maximal inhibitory concentration: 230 nM
Beside the measured number, compound 4's estimate is 1.0-fold (0.02 log units) below it; the measured number falls inside the stated range.
By their numbers in this assay, from the lowest: compounds 2, 4, 3 and 1 (each within the scatter of the next).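

In this assay, the 2,3-dimethylphenyl group on a sulfonamide nitrogen stays within the scatter of all three earlier aryl groups (a 1.0-fold lower number from compound 3 to compound 4 (0.02 log units; within the scatter); a 1.5-fold lower number from compound 1 to compound 4 (0.18 log units; within the scatter)). For the compounds shown here, the single change of methyl in place of hydrogen on an aromatic carbon also stays within it (a 1.2-fold higher number from compound 2 to compound 4 (0.08 log units; within the scatter)), so this small addition to the ring produces no separable step. Nothing available explains this lack of separation. Every group shown at this nitrogen is a hydrocarbon-substituted or brominated phenyl, so whether a phenyl bearing an amine or a carboxylic acid would step beyond the scatter remains open.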